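This account rests on a few compounds, and the source may have more. Where it says the series, first, only, none or still open, it means among the compounds named here.

Measured compounds:
compound 1 `NCCCOc1ccc(CNc2nc3ccc(Oc4ccc(O)cc4)cc3s2)cc1` — 300000 nM
compound 2 `NCCCOc1ccc(CNc2nc3ccc(Oc4cccc(C(F)(F)F)c4)cc3s2)cc1` — 171000 nM

In an assay on cells for inhibition of Voltage-dependent T-type calcium channel subunit alpha-1H (Homo sapiens), read by FLIPR and calcium flux, with stated times of 600 s and 300 s (a lower number here means a stronger inhibitor, a higher number a weaker inhibitor), compound 1 gives 300000 nM, the highest of the two numbers. Among the measured compounds shown here, its only neighbour, compound 2, gives 171000 nM, and the step of a 1.8-fold lower number from compound 1 to compound 2 (0.24 log units; within the scatter) stays within the scatter, so the two values cannot be ordered. The unmeasured compound 3 `CN(Cc1ccc(OCCCN)cc1)c1nc2ccc(Oc3ccc(O)cc3)cc2s1` differs from compound 1 by methyl in place of hydrogen on a nitrogen on an aromatic ring. For the measured compounds named here, no measured step touches that nitrogen: the one step known, a 1.8-fold lower number from compound 1 to compound 2 (0.24 log units; within the scatter), concerns a change on an oxygen on an aromatic ring and was itself within the scatter, so nothing in the measured pair argues for a shift beyond the scatter in this assay. Compound 3 is therefore expected to come out near 300000 nM, with a range of 100000 nM to 900000 nM. That estimate means an expected step of no change at the digits printed from compound 1 to compound 3 (within the scatter), judged to lie within the scatter.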

Compound 3, half-maximal inhibitory concentration: 165000 nM
The estimate for compound 3 lay 1.8-fold (0.26 log units) above the measured number; the range from low to high includes it.
By their numbers in this assay, from the lowest: compounds 3, 2 and 1 (each within the scatter of the next).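

In this assay, among the compounds shown here, the first change at this nitrogen gives a 1.8-fold lower number from compound 1 to compound 3 (0.26 log units; within the scatter), so methyl can stand in place of hydrogen here without a step beyond the scatter. For the compounds shown here, until now, the only measured change had been on the oxygen on an aromatic ring, and this result extends the same reading to a second place on the molecule: neither single change separates its pair of compounds. No measurement is available that would explain the values at this nitrogen.

On these data alone, it remains open whether an ethyl or acetyl group on the same nitrogen would give a step beyond the scatter. As far as these compounds go, it is also open whether methyl would give a similar step with 3-(trifluoromethyl)phenyl in place of 4-hydroxyphenyl, or whether a longer chain or a carboxylic acid in place of the amine would matter more.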